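The source may hold more compounds than are shown below. What is called first, only, known or untested is meant among the compounds shown, and "the series" means these compounds.

Compound 1 `C/C(=C\COc1c(Cl)cccc1Cl)CC/C=C(\C)C1CC(=O)C(C)(C)O1` was tested in a functional assay on L1210 cells (Mus musculus) for inhibition (a higher number here means a weaker inhibitor, a lower number a stronger inhibitor), where compound 1 gives 58 ug/mL. Its companions differ only in the aryl group on the oxygen: compound 2 `COc1cccc(OC/C=C(\C)CC/C=C(\C)C2CC(=O)C(C)(C)O2)c1` gives 66.5 ug/mL and compound 3 `C/C(=C\COc1ccccc1)CC/C=C(\C)C1CC(=O)C(C)(C)O1` gives 64 ug/mL. The steps of a 1.1-fold higher number from compound 1 to compound 2 (0.06 log units; within the scatter), a 1.1-fold higher number from compound 1 to compound 3 (0.04 log units; within the scatter) and a 1.0-fold lower number from compound 2 to compound 3 (0.02 log units; within the scatter) all lie within the scatter, so the three numbers cannot be ranked. Compound 4 `C/C(=C\COc1c(Cl)cccc1Cl)CC/C=C(\C)C1=CC(=O)C(C)(C)O1` keeps the dichlorophenyl ether of compound 1 and changes the ring end of the chain: a group of 8 heavy atoms (6 carbon, 2 oxygen; one five-membered non-aromatic ring with 1 hetero atom) in place of a group of 8 heavy atoms (6 carbon, 2 oxygen; one five-membered non-aromatic ring with 1 hetero atom), on a double-bonded chain carbon bound to a double-bonded chain carbon and a saturated chain carbon. Within the data shown here, none of the measured steps touches this part of the molecule, so no measured step bears on it. In the absence of such data the expectation rests on compound 1 alone, and the step of a 1.2-fold lower number from compound 1 to compound 4 (0.06 log units; within the scatter) is expected to stay within the scatter, with a wide allowance in both directions. Compound 4 is therefore estimated at 50 ug/mL, between 12 ug/mL and 200 ug/mL.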

Compound 4, half-maximal inhibitory concentration: 30.7 ug/mL
Estimate against measurement, compound 4: 1.6-fold (0.21 log units) above; measured number inside the range.
By their numbers in this assay, from the lowest: compounds 4, 1, 3 and 2 (each within the scatter of the next, the first and the last beyond it).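

In this assay, the only change shown at the ring end of the chain gives a 1.9-fold lower number from compound 1 to compound 4 (0.28 log units; within the scatter). At this place, on a double-bonded chain carbon, the 5,5-dimethyl-4-oxooxolan-2-yl group can thus give way to a ring with 2 double bonds outside aromatic rings without a step beyond the scatter. Nothing at hand accounts for this step. Still open, from the compounds shown here alone, is whether the same ring change reads alike with the phenyl or 3-methoxyphenyl ethers, and how an amine or a carboxylic acid in place of the ring would read in this assay.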